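The compounds below may be only part of what the source reports. "The series", "measured", "known", "first", "only" and "open" are said of these compounds alone.

Compound 2 `OCCCCc1cn(CCNc2nonc2/C(=N/O)Nc2ccc(F)c(Br)c2)nn1` is one of two compounds for which a number is known in an assay on isolated protein for inhibition of Indoleamine 2,3-dioxygenase 2 (Homo sapiens) (a higher number here means a weaker inhibitor, a lower number a stronger inhibitor), where compound 2 gives 1080 nM. Its neighbour is compound 1 `CCCCc1cn(CCNc2nonc2/C(=N/O)Nc2ccc(F)c(Br)c2)nn1`, which in this assay gives 830 nM; the two stand close together, separated only by a 1.3-fold higher number from compound 1 to compound 2 (0.11 log units; within the scatter). Compound 3 `O/N=C(\Nc1ccc(F)c(Br)c1)c1nonc1NCCn1cc(C2(O)CCCCC2)nn1` differs from compound 2 by 1-hydroxycyclohexyl in place of 4-hydroxybutyl on an aromatic carbon. Among the compounds with values here, the one measured step concerns only the hydroxy on the 4-hydroxybutyl chain and bears loosely on the exchange of that chain for a 1-hydroxycyclohexyl, since no measured pair exchanges a chain for a ring at this carbon. With the hydroxy-bearing substituent retained and no step beyond the scatter seen so far, compound 3 is expected to land near compound 2, with an estimated shift of a 1.1-fold lower number from compound 2 to compound 3 (0.03 log units; within the scatter). The estimate for compound 3 in this assay is therefore 1000 nM, within a range from 400 nM to 2500 nM.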

Compound 3, half-maximal inhibitory concentration: 865 nM
Compound 3: the middle estimate sits 1.2-fold (0.06 log units) above what was measured; the range from low to high includes it.
By their numbers in this assay, from the lowest: compounds 1, 3 and 2 (each within the scatter of the next).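

In this assay, 1-hydroxycyclohexyl in place of 4-hydroxybutyl on this aromatic carbon gives a 1.2-fold lower number from compound 2 to compound 3 (0.10 log units; within the scatter), and 1-hydroxycyclohexyl in place of butyl gives a 1.0-fold higher number from compound 1 to compound 3 (0.02 log units; within the scatter). The earlier compounds shown here covered only open chains at this position, whereas compound 3 shows that a six-membered non-aromatic ring of carbon only, with 7 heavy atoms in place of 5, leaves the number within the scatter of both open-chain compounds. No measured evidence accounts for this.

What these three compounds leave open is whether a plain cyclohexyl ring without the hydroxy would stay in the same range. Going by these compounds, it is equally open whether an amine, a carboxylic acid or a longer chain on this aromatic carbon would move the number beyond the scatter.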